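The source may report more compounds than this note shows. Statements on the series, on what has been measured and on what is new or still open speak of the compounds shown alone.

The series shares one core, and its members are compound 1 `O=C(CCc1ccccc1)Nc1ccc2sc(C(=O)NO)cc2c1`, compound 2 `CN(C)CCCC(=O)Nc1ccc2cc(C(=O)NO)sc2c1`, compound 3 `CN(C(=O)CCc1ccccc1)c1ccc2cc(C(=O)NO)sc2c1` and the as yet unmeasured compound 4 `CN(C(=O)CCc1ccccc1)c1ccc2sc(C(=O)NO)cc2c1`. In a physicochemical assay for solubility, at pH 7.4 (on this read-out lower numbers stand for lower solubility and higher numbers for higher solubility), compound 1 gives 4 ug/mL. Among the compounds with values here, compound 3 gives 4 ug/mL in this assay, a number level with that of compound 1 within the scatter of the method, so the two stand together at the low end of the three numbers known. Compound 2 gives 1310 ug/mL in this assay, a far higher number that lies well beyond the scatter from compound 1.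

The step from compound 1 to compound 4 is a single small change: methyl in place of hydrogen on an amide-type nitrogen. Within the data shown here, no measured pair shows this change on its own. What is known is that compound 3, which also carries a methyl on its amide-type nitrogen, gives 4 ug/mL, a number indistinguishable from compound 1. The step of no change at the digits printed from compound 1 to compound 4 (within the scatter) is therefore expected to be small, with no direction that rises above the scatter. Compound 4 is estimated at 4 ug/mL in this assay, within a range from 1.5 ug/mL to 12 ug/mL.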

Compound 4, solubility: 4 ug/mL
Beside the measured number, compound 4's estimate shows no gap at the digits printed; the range from low to high includes it.
By their numbers in this assay, from the lowest: compounds 1, 3 and 4 (each within the scatter of the next); then compound 2.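

In this assay, within the data shown here, the earlier compounds held no pair that isolated this change, and the new pair does: methyl in place of hydrogen on an amide-type nitrogen, whose other neighbours are an aromatic carbon and a carbonyl carbon, gives no change at the digits printed from compound 1 to compound 4 (within the scatter). With the shared core and this chain held constant, the methyl and the amide hydrogen cannot be told apart on this read-out. No measurement shown accounts for this result.

The compounds shown leave open whether an ethyl or a longer chain on the same nitrogen would read the same way. They also leave open whether the methyl would give the same step if the chain on the carbonyl ended in a morpholine or a carboxylic acid, or if it were the chain of compound 2.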